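Swapping a Ring on the Amine: Effect on Maximal Response

The source may hold more compounds than are shown below. What is called first, only, known or untested is meant among the compounds shown, and "the series" means these compounds.

Compound 1 `CS(=O)(=O)c1cnc(O[C@H]2CC[C@H](OC3CCN(C(=O)C4(C(F)(F)F)CCCC4)CC3)CC2)cn1` and compound 2 `CS(=O)(=O)c1cnc(O[C@H]2CC[C@H](OC3CCN(CC4(C(F)(F)F)CC4)CC3)CC2)cn1` share one core and differ only on the amine nitrogen in a ring. In a functional assay on isolated protein for agonist activity at Glucose-dependent insulinotropic receptor (Rattus norvegicus), read by HTRF and cAMP accumulation (on this read-out lower numbers stand for smaller maximal responses and higher numbers for larger maximal responses), compound 1 gives 124%, and compound 2 gives 124%; the step of no change at the digits printed from compound 1 to compound 2 (within the scatter) lies within the scatter, so compound 2 stands level with compound 1. Compound 3 `CC(C)c1noc(CN2CCC(O[C@H]3CC[C@H](Oc4cnc(S(C)(=O)=O)cn4)CC3)CC2)n1` carries 3-isopropyl-1,2,4-oxadiazol-5-yl in place of 1-(trifluoromethyl)cyclopropyl on a saturated chain carbon bound to an amine nitrogen in a ring. Within the data shown here, only that one measured step bears on this change, and it was flat, so a step of a number 6 percentage points lower from compound 2 to compound 3 (within the scatter) is expected, within the scatter. Compound 3 is therefore estimated at 118%, between 95% and 138%.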

Compound 3, largest response reached (Emax), in percent of the reference or control that the assay uses: 115%
The estimate for compound 3 lay 3 percentage points above the measured number; measured number inside the range.
By their numbers in this assay, from the lowest: compounds 3, 1 and 2 (each within the scatter of the next).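

Among these compounds, putting 3-isopropyl-1,2,4-oxadiazol-5-yl in place of 1-(trifluoromethyl)cyclopropyl brings an aromatic ring with 3 hetero atoms to this position, where the earlier compounds held carbon-only rings, and this assay shows a number 9 percentage points lower from compound 2 to compound 3 (within the scatter). The comparison with the larger group of the first compound gives a number 9 percentage points lower from compound 1 to compound 3 (within the scatter). So at this position, the maximal response of these three compounds stays within the scatter, even with 3 hydrogen-bond acceptors entering.

Nothing available explains this result. As far as these compounds go, whether a carboxylic acid or a primary amine at this place would give a step beyond the scatter remains open.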